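This account rests on a few compounds, and the source may have more. Where it says the series, first, only, none or still open, it means among the compounds named here.

In an assay on CHO cells for displacement of a labelled ligand from adenosine receptor A1 (Homo sapiens), read by scintillation counting, with a stated time of 120 min, tested at 10 uM (a lower number here means less inhibition, a higher number more inhibition at the concentration tested (going by the name of the read-out)), three close relatives of one shared core have been tested so far. Compound 1 `COc1ccc(N2CCN(Cc3csc(N)c3C(=O)c3ccc(Cl)cc3)CC2)cc1` gives 0% in this assay. Compound 2 `Nc1scc(CN2CCN(c3ccc([N+](=O)[O-])cc3)CC2)c1C(=O)c1ccc(Cl)cc1` gives 1%, and compound 3 `Nc1scc(CN2CCN(c3ccncc3)CC2)c1C(=O)c1ccc(Cl)cc1` gives 1%. Compound 3 stands level with compound 2 at the digits printed, and the step of a number 1 percentage points higher from compound 1 to compound 3 (within the scatter) as well as the step of no change at the digits printed from compound 2 to compound 3 (within the scatter) both lie within the scatter, so the three numbers cannot be told apart.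

The next compound, compound 4 `Nc1scc(CN2CCN(c3cccc(F)c3)CC2)c1C(=O)c1ccc(Cl)cc1`, differs from compound 3 in one place: 3-fluorophenyl in place of pyridin-4-yl on an amine nitrogen in a ring. Two of the measured steps bear directly on this change, since both also swap the group on that same amine nitrogen in a ring: a number 1 percentage points higher from compound 1 to compound 3 (within the scatter) exchanged 4-methoxyphenyl for pyridin-4-yl, and no change at the digits printed from compound 2 to compound 3 (within the scatter) exchanged 4-nitrophenyl for pyridin-4-yl, neither moving the read-out beyond the scatter. On that basis one expects a step of a number 1 percentage points higher from compound 3 to compound 4 (within the scatter) that is no larger than the scatter, with no direction favoured. Compound 4 is therefore estimated to give 2% in this assay, within a range from -8% to 12%.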

Compound 4, a percentage reported as inhibition, at one concentration (the size of the read-out at that concentration, not a potency): 1%
Estimate against measurement, compound 4: 1 percentage points above, within the range that was stated.
By their numbers in this assay, from the lowest: compounds 1, 2, 3 and 4 (each within the scatter of the next).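

In this assay, the exchange of a ring holding a nitrogen and a hydrogen-bond acceptor for a ring of carbon only, now carrying fluorine, gives no change at the digits printed from compound 3 to compound 4 (within the scatter), so neither the ring nitrogen nor the acceptor of pyridin-4-yl is needed to keep the number where it stood. The same holds when the new group is set against the two substituted phenyl groups, with no change at the digits printed from compound 2 to compound 4 (within the scatter) and a number 1 percentage points higher from compound 1 to compound 4 (within the scatter), so all four groups on this amine nitrogen in a ring give numbers that cannot be told apart, and the position has so far shown no response to any change. Nothing among the data shown accounts for this flat result.

Going by these compounds, all four groups on that nitrogen are six-membered aromatic rings, so it remains open whether a benzyl group, a cyclohexyl ring or a short alkyl chain there would move the number beyond the scatter. On these data alone, the 4-chlorophenyl ketone and the free amine of the shared core stay the same throughout, and what an amide in place of that amine or a plain phenyl ketone would give is equally open.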